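The source may report more compounds than this note shows. Statements on the series, on what has been measured and on what is new or still open speak of the compounds shown alone.

Series notes. Among the measured compounds shown here, in a functional assay on T-24 cells (Homo sapiens) for antiproliferative activity, read by MTT assay, with a stated time of 48 h (a higher number here means a weaker inhibitor, a lower number a stronger inhibitor), compound 2 `CCc1ccc(NC(=O)Nc2cccc(CNc3nccnc3Cl)c2)c(CC)c1` gives 6390 nM, the only number so far recorded for the set. Compound 1 `O=C(Nc1cccc(CNc2nccnc2Cl)c1)Nc1cccc2ccccc12` gives > 40000 nM in this assay, which is a limit of the assay rather than a number. The set contains (the limit of > 40000 nM in this assay, at which 1 of the 2 values shown sits). Compound 2 stands alone as the sole measured point, with nothing measured beside it to show how far any single change moves the readout. The next compound, compound 3 `CCc1ccccc1NC(=O)Nc1cccc(CNc2nccnc2Cl)c1`, is to be measured in this assay. It differs from compound 2 in one place: hydrogen in place of ethyl on an aromatic carbon. For the measured compounds named here, no step between measured compounds exists, so the expectation rests on compound 2 alone. A loss of potency somewhat beyond the scatter is expected, and the estimated step in this assay is a 1.9-fold higher number from compound 2 to compound 3 (0.27 log units; within the scatter). Compound 3 is expected to give about 12000 nM in this assay, with a range from 4000 nM to 40000 nM.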

Compound 3, half-maximal inhibitory concentration: 8720 nM
Compound 3: middle estimate off by 1.4-fold (0.14 log units), on the high side, within the range that was stated.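

In this assay, hydrogen in place of ethyl on the aromatic carbon para to a large group gives a 1.4-fold higher number from compound 2 to compound 3 (0.14 log units; within the scatter). Among the compounds shown here, this is the first step measured, and it shows that compound 2 and compound 3 cannot be told apart in this readout, so the ethyl group at this position is not required to keep the value in the range of compound 2. No measurement at hand gives a cause for this step.

From the compounds shown here alone, only ethyl and hydrogen are compared at this position, so the effect of an amine, a carboxylic acid or a longer chain there remains open in this assay. Also open is what the remaining ethyl group contributes, since no pair of compounds shown isolates a change at that group.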